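Cyanomethoxy for ethylsulfinyl on the dichlorophenyl core

The source may hold more compounds than are shown below. What is called first, only, known or untested is meant among the compounds shown, and "the series" means these compounds.

Compound 1 `CCO/N=C/Nc1cc(Cl)c([S+]([O-])CC)c(Cl)c1` gives 2.9 in a physicochemical assay for lipophilicity, measured as octanol-water partition (a higher number here means a more lipophilic compound, a lower number a more polar compound), the second highest of three numbers; compound 2 `CCO/N=C/Nc1cc(Cl)c(S(=O)(=O)CC)c(Cl)c1` gives 2.8, and compound 3 `C=CCOc1c(Cl)cc(N/C=N/OCC)cc1Cl` gives 4.3. The step of a number 0.10 log units lower from compound 1 to compound 2 (within the scatter) lies within the scatter, whereas a number 1.40 log units higher from compound 1 to compound 3 (beyond the scatter) and a number 1.50 log units higher from compound 2 to compound 3 (beyond the scatter) are large. Compound 4 `CCO/N=C/Nc1cc(Cl)c(OCC#N)c(Cl)c1` differs from compound 1 by a group of 4 heavy atoms (2 carbon, 1 nitrogen, 1 oxygen; no ring) in place of a group of 4 heavy atoms (2 carbon, 1 oxygen, 1 sulfur; no ring), on an aromatic carbon. Of the measured steps, only a number 1.40 log units higher from compound 1 to compound 3 (beyond the scatter) bears on this change, and it replaced the same group of 4 heavy atoms with an oxygen-bearing group; the entering cyanomethoxy carries a nitrogen and a second acceptor instead, so a smaller rise is expected. Compound 4 is therefore estimated at 3.2, range 2.6 to 3.8, meaning an expected step of a number 0.30 log units higher from compound 1 to compound 4 (within the scatter).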

Compound 4, partition coefficient: 3.1
The estimate for compound 4 lay 0.10 log units above the measured number; the range from low to high includes it.
By their numbers in this assay, from the lowest: compounds 2, 1 and 4 (each within the scatter of the next); then compound 3.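

In this assay, cyanomethoxy on this aromatic carbon gives a number 0.20 log units higher from compound 1 to compound 4 (within the scatter) against ethylsulfinyl and a number 0.30 log units higher from compound 2 to compound 4 (within the scatter) against ethylsulfonyl, so the three groups are not separated here. The ether oxygen on the aromatic carbon is shared by compound 3 and compound 4, yet cyano in place of vinyl on the saturated chain carbon gives a number 1.20 log units lower from compound 3 to compound 4 (beyond the scatter). The high number of compound 3 therefore does not follow from that oxygen alone.

As far as these compounds go, whether an amine or a carboxylic acid on this aromatic carbon would stand with compound 4 or with compound 3 remains open. No available evidence accounts for these steps.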